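Dihydroxyphenyl Replaces a Halogenated Aryl on the Hydrazone Carbon

The source may report more compounds than this note shows. Statements on the series, on what has been measured and on what is new or still open speak of the compounds shown alone.

Compound 3 `CN(C)CCn1cnnc1-c1cc(Oc2ccc(NC(=O)N/N=C/c3ccc(F)cc3Cl)cc2F)ccn1` gives the lowest of the three numbers measured in a functional assay on HT-29 cells (Homo sapiens) for cytotoxicity, read by MTT assay, with a stated time of 72 h; on this read-out higher numbers stand for weaker inhibition and lower numbers for stronger inhibition; compound 3 gives 510 nM. Compound 2 `CN(C)CCn1cnnc1-c1cc(Oc2ccc(NC(=O)N/N=C/c3ccc(Cl)cc3)cc2F)ccn1` stands nearest to it, and in this assay compound 2 gives 530 nM, so that a 1.0-fold lower number from compound 2 to compound 3 (0.02 log units; within the scatter). Compound 1 `COc1cc(/C=N/NC(=O)Nc2ccc(Oc3ccnc(-c4nncn4CCN(C)C)c3)c(F)c2)cc(OC)c1OC` stands furthest away; in this assay compound 1 gives 3620 nM. The two steps leading away from compound 1 were a 6.8-fold lower number from compound 1 to compound 2 (0.83 log units; beyond the scatter) and a 7.1-fold lower number from compound 1 to compound 3 (0.85 log units; beyond the scatter), each exchanging the methoxy-bearing aryl of compound 1 for a halogenated aryl on the carbon with a double bond to nitrogen.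

Compound 4 `CN(C)CCn1cnnc1-c1cc(Oc2ccc(NC(=O)N/N=C/c3ccc(O)cc3O)cc2F)ccn1` carries a further change at that same carbon: 2,4-dihydroxyphenyl in place of 2-chloro-4-fluorophenyl on a carbon with a double bond to nitrogen. Among the compounds with values here, no measured step introduces hydroxyl groups, so the bearing of the earlier steps is indirect. The one aryl carrying oxygen substituents, in compound 1, gave the highest number, while the halogenated aryls gave the lowest two. On that basis the step from compound 3 to compound 4 is expected to run toward a higher number, of moderate size, as a 2.9-fold higher number from compound 3 to compound 4 (0.47 log units; beyond the scatter). Compound 4 is therefore estimated to give 1500 nM, with a range from 500 nM to 5000 nM.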

Compound 4, half-maximal inhibitory concentration: 52600 nM
The estimate for compound 4 lay 35-fold (1.54 log units) below the measured number, and the stated range ends below it.
By their numbers in this assay, from the lowest: compounds 3 and 2 (each within the scatter of the next); then compound 1; then compound 4.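

In this assay, the aryl on a carbon with a double bond to nitrogen turns out to control a far wider span than compound 1, compound 2 and compound 3 had revealed: exchanging either halogenated aryl for 2,4-dihydroxyphenyl gives large steps (a 100-fold higher number from compound 3 to compound 4 (2.01 log units; beyond the scatter); a 99-fold higher number from compound 2 to compound 4 (2.00 log units; beyond the scatter)). Oxygen substituents at this carbon also do not behave as one class, since the exchange of 3,4,5-trimethoxyphenyl for 2,4-dihydroxyphenyl is itself a large step (a 15-fold higher number from compound 1 to compound 4 (1.16 log units; beyond the scatter)), so the trimethoxy compound's place among the first three gave no measure of how far a hydroxylated aryl would lie. Nothing at hand accounts for the size of these steps.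

The compounds shown leave open whether both hydroxyl groups are needed for this loss or whether a single hydroxyl on the same aryl would bring it about, and whether methylating them would restore the lower numbers of the halogenated aryls. They also leave open how an aryl bearing an amine or a carboxylic acid would stand at this carbon.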